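The source may report more compounds than this note shows. Statements on the series, on what has been measured and on what is new or still open speak of the compounds shown alone.

Measured so far:
compound 1 `Cc1ccc(CNc2ncnc3c2ncn3[C@@H]2O[C@H](CO)[C@@H](O)[C@H]2O)cc1` — > 166000 nM
compound 2 `COc1cccc(CNc2ncnc3c2ncn3[C@@H]2O[C@H](CO)[C@@H](O)[C@H]2O)c1OC` — > 166000 nM

In a functional assay on HOS cells (Homo sapiens) for antiproliferative activity, with a stated time of 72 h (a lower number here means a stronger inhibitor, a higher number a weaker inhibitor), compound 1 gives only a limit, > 166000 nM. Compound 2 likewise gives only a limit in this assay, > 166000 nM. The step that the two limits leave unreadable from compound 1 to compound 2 is therefore unreadable, since both readings sit at the limit of > 166000 nM in this assay, at which 2 of the 2 values shown sit. Compound 2 thus stands at the limit with no number to place it against.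

Compound 3 `OC[C@H]1O[C@@H](n2cnc3c(NCc4ccc(F)c(F)c4F)ncnc32)[C@H](O)[C@@H]1O` is not yet measured; the change is 2,3,4-trifluorophenyl in place of 2,3-dimethoxyphenyl on a saturated chain carbon bound to a nitrogen on an aromatic ring. Only the unreadable step bears on it, so no readable size of step is on hand. Compound 3 is expected to stay at or near the limit, with a step that the limit leaves unreadable from compound 2 to compound 3 expected to be none beyond the scatter. The estimate for compound 3 is 200000 nM, within 100000 nM to 500000 nM.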

Compound 3, half-maximal inhibitory concentration: > 166000 nM
Compound 3 was reported as a limit (the forecaster's own chance of this, stated with the estimate: 85%); the middle value lies beyond the limit too.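

Compound 3 also gives only a limit in this assay, > 166000 nM, so no step among compound 1, compound 2 and compound 3 can be read: the limit of > 166000 nM in this assay, at which 3 of the 3 values shown sit.

Still open, going by these compounds, is whether any aryl group in this place on the shared core gives a readable value.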